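Series notes: cytotoxicity limits and one open estimate

The source may report more compounds than this note shows. Statements on the series, on what has been measured and on what is new or still open speak of the compounds shown alone.

Measured so far:
- compound 1 `C=C1CC[C@H]2C(C)(C)CCC[C@]2(C)[C@H]1CC/C(C)=C/COc1cc(O)c2c(=O)c(O)c(-c3ccc(OC)cc3)oc2c1`: in a functional assay on HeLa cells (Homo sapiens) for cytotoxicity, read by XTT assay, with a stated time of 72 h (on this read-out lower numbers stand for stronger inhibition and higher numbers for weaker inhibition), compound 1 gives > 100000 nM, which is a limit of the assay and not a number.
- compound 2 `C=C1CC[C@H]2C(C)(C)CCC[C@]2(C)[C@H]1CC/C(C)=C/COc1cc(O)c2c(=O)c(OC/C=C(\C)CC[C@H]3C(=C)CC[C@H]4C(C)(C)CCC[C@]34C)c(-c3ccc(OC)cc3)oc2c1`: in this assay compound 2 gives > 100000 nM, again a limit of the assay.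
- compound 3 `C=C1CC[C@H]2C(C)(C)CCC[C@]2(C)[C@H]1CC/C(C)=C/COc1cc(O)c2c(=O)c(O)c(-c3ccc(O)cc3)oc2c1`: in this assay compound 3 gives > 100000 nM, also a limit of the assay.

All three values recorded so far sit at the limit of > 100000 nM in this assay, at which 3 of the 3 values shown sit, so none of them is a real number and no ordering among the three compounds can be read. Compound 3 differs from compound 1 by hydrogen in place of methyl on an oxygen on an aromatic ring. The step that the two limits leave unreadable from compound 1 to compound 3 is therefore unreadable: both ends are limits, and its size is not known. How the core of compound 2 differs from the core of compound 1 is not broken down here.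

Compound 4 `C=C1CC[C@H]2C(C)(C)CCC[C@]2(C)[C@H]1CC/C(C)=C/COc1cc(O)c2c(=O)c(OC/C=C(\C)CC[C@H]3C(=C)CC[C@H]4C(C)(C)CCC[C@]34C)c(-c3ccc(O)cc3)oc2c1` is not yet measured. It comes from compound 2 by hydrogen in place of methyl on an oxygen on an aromatic ring, the same change as that from compound 1 to compound 3, and the surroundings of the place are the same in both cases. Among the compounds with values here, the only evidence on this change is that compound 1 and compound 3 both stayed at their limits, which gives no readable size. With compound 2 also at its limit, the expectation is that the step that the limit leaves unreadable from compound 2 to compound 4 will be small and that compound 4 will again report only a limit. Compound 4 is estimated at 150000 nM in this assay, with an expected range from 50000 nM to 500000 nM.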

Compound 4, half-maximal inhibitory concentration: > 100000 nM
Compound 4 was reported as a limit; the forecaster's own chance of this, stated with the estimate: 85%; the middle value is on the limit's open side.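

In this assay compound 4 gives > 100000 nM as a limit of the assay and not a number. Compound 2 also stands at a limit, so no new step can be read between compound 2 and compound 4, and the series still has no ordering: the limit of > 100000 nM in this assay, at which 4 of the 4 values shown sit.

The compounds shown leave open whether methoxy to hydroxy has any effect on this read-out, and whether any compound in the series reaches a real value.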